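A few compounds are considered here, and "the series" means these few. Any claim that something is new, unique, unknown or untested is made for them only; others in the source may bear on it.

Working notes, permeability series on a shared core.

Compound 1 `CC(C)C(=O)NCCS(=O)(=O)NC(=O)c1ccc(Nc2nc(NC3(c4ccc(Cl)cc4)CC3)nc(OCC(F)(F)F)n2)cc1` is measured in a physicochemical assay for permeability, using PAMPA, at pH 7.4 (on this read-out higher numbers stand for higher permeability and lower numbers for lower permeability), at 13 nm/s. Compound 2 `CS(=O)(=O)NC(=O)c1ccc(Nc2nc(NC3(c4ccc(Cl)cc4)CC3)nc(OCC(F)(F)F)n2)cc1` gives 11 nm/s in this assay, and compound 3 `CC(=O)NCCS(=O)(=O)NC(=O)c1ccc(Nc2nc(NC3(c4ccc(Cl)cc4)CC3)nc(OCC(F)(F)F)n2)cc1` gives 7 nm/s. The three values sit together: the step of a 1.2-fold lower number from compound 1 to compound 2 (0.07 log units; within the scatter) and the step of a 1.9-fold lower number from compound 1 to compound 3 (0.27 log units; within the scatter) both fall inside the scatter, as does the step of a 1.6-fold lower number from compound 2 to compound 3 (0.20 log units; within the scatter), so no compound stands apart on the numbers shown.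

Compound 4 `CC(C)NC(=O)NCCS(=O)(=O)NC(=O)c1ccc(Nc2nc(NC3(c4ccc(Cl)cc4)CC3)nc(OCC(F)(F)F)n2)cc1` is not yet measured. Against compound 1 the change is isopropylamino in place of isopropyl on a carbonyl carbon.

For the measured compounds named here, the measured step that bears most directly on this change is the one from compound 1 to compound 3, which also alters the group on that carbonyl carbon and came out at a 1.9-fold lower number from compound 1 to compound 3 (0.27 log units; within the scatter). Removing the whole chain on the saturated carbon bound to the sulfonyl sulfur, a 1.2-fold lower number from compound 1 to compound 2 (0.07 log units; within the scatter), likewise stayed within the scatter. On this basis no step beyond the scatter is expected in this assay; compound 4 is estimated at 10 nm/s, with a range from 4 nm/s to 25 nm/s, meaning an expected step of a 1.3-fold lower number from compound 1 to compound 4 (0.11 log units; within the scatter).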

Compound 4, apparent permeability: 45 nm/s
For compound 4 the middle estimate is 4.5-fold (0.65 log units) below the measured one; the measured number lies above the stated range.
By their numbers in this assay, from the lowest: compounds 3, 2 and 1 (each within the scatter of the next); then compound 4.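

On the carbonyl carbon, isopropylamino in place of isopropyl produces a step beyond the scatter in this assay (a 3.5-fold higher number from compound 1 to compound 4 (0.54 log units; beyond the scatter)), so this position can move the read-out, which the three closely grouped earlier values did not show. Compound 4 also stands apart from the other two compounds, both with isopropylamino in place of methyl on the carbonyl carbon (a 6.4-fold higher number from compound 3 to compound 4 (0.81 log units; beyond the scatter)) and with ((isopropylcarbamoyl)amino)methyl in place of hydrogen on the saturated chain carbon bound to a sulfonyl sulfur (a 4.1-fold higher number from compound 2 to compound 4 (0.61 log units; beyond the scatter)). Nothing at hand accounts for this step.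

Still open, as far as these compounds go, is whether the step depends on the nitrogen or on the isopropyl group attached to it, which a methylamino group on the same carbonyl carbon would help separate. An isopropoxy group at that place would show whether a nitrogen is needed at all.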